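The source may hold more compounds than are shown below. What is called first, only, known or untested is meant among the compounds shown, and "the series" means these compounds.

Measured compounds in a functional assay for antagonist activity at transient receptor potential cation channel subfamily V member 1 (Rattus norvegicus), read by FLIPR; a lower number here means a less potent compound, a higher number a more potent compound, by a factor of ten per unit of this negative logarithm:
compound 1, `O=C(Nc1ccccc1Br)N[C@@H]1CCN(c2cccc(C(F)(F)F)n2)C1`, gives 7.2 
compound 2, `O=C(Nc1ccccc1Br)N[C@@H]1CCN(c2ccccn2)C1`, gives < 6.6 

Compound 2 stands only at a limit of this assay, not at a number, (the limit of < 6.6 in this assay, at which 1 of the 2 values shown sits). Among the measured compounds shown here, the single measured step, a number at least 0.60 log units lower from compound 1 to compound 2 (beyond the scatter), shows that removing the trifluoromethyl from the pyridin-2-yl ring costs potency, and the true size of that loss is open since compound 2 is at the limit.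

Compound 3, `O=C(Nc1ccccc1Br)N[C@@H]1CCN(c2ccc(Cl)cn2)C1`, goes the other way: chloro in place of hydrogen on an aromatic carbon. The incoming chloro is a smaller group than the trifluoromethyl it follows in spirit, and it sits on the same ring but at a different aromatic carbon, so the step from compound 1 to compound 2 bears on it only as a sign that substitution on this ring matters. A gain over compound 2 in this assay is therefore expected, though its size is uncertain, and the expected step is a number at least 0.40 log units higher from compound 2 to compound 3 (beyond the scatter). The estimate for compound 3 is 7, within a range of 6.3 to 7.7.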

Compound 3, negative logarithm of the antagonist equilibrium constant: 7.3
For compound 3 the middle estimate is 0.30 log units below the measured one, and the stated range covers the measured number.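

In this assay, the 5-chloropyridin-2-yl ring of compound 3 shows that this carbon, two atoms from the ring nitrogen and para to a large group, also responds to substitution: a number at least 0.70 log units higher from compound 2 to compound 3 (beyond the scatter). Among the compounds shown here, until now the only evidence on the pyridin-2-yl ring tied a gain to trifluoromethyl at a different carbon, whereas here a single chloro, one heavy atom, is enough for a gain beyond the scatter. Compound 2 stands at a limit, not at a number: the limit of < 6.6 in this assay, at which 1 of the 3 values shown sits.

The compounds shown leave open whether the gain is specific to chloro or would also hold for fluoro, methyl, methoxy, nitrile or an amine at this carbon. Also open, on these data alone, is whether chloro and trifluoromethyl would combine on one ring, and compound 1 and compound 3 differ in more than one place, so they offer no direct comparison of the two groups.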